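The source may report more compounds than this note shows. Statements on the series, on what has been measured and on what is new or still open speak of the compounds shown alone.

In a toxicity assay on HUVEC cells (Homo sapiens) for inhibition (a lower number here means a stronger inhibitor of growth, a higher number a weaker inhibitor of growth), compound 1 `O=C(OCc1ccccc1)c1ccsc1NC(=O)[C@@H]1CCCN1` reaches only the assay limit of > 250 ug/mL, so no number is known for it. Compound 3 `O=C(OCC(Cl)(Cl)Cl)c1ccsc1NC(=O)[C@@H]1CCCN1` likewise stops at the limit of > 250 ug/mL in this assay. The step that the two limits leave unreadable from compound 1 to compound 3 is therefore unreadable, as the two limits hide its size. Compound 2 `COC(=O)c1ccsc1NC(=O)[C@H]1CCCN1`, a close relative, gives 95.8 ug/mL in this assay. The unmeasured compound 4 `COC(=O)c1ccsc1NC(=O)[C@@H]1CCCN1` differs from compound 1 by hydrogen in place of phenyl on a saturated chain carbon bound to an oxygen next to a carbonyl group. Among the compounds with values here, no measured step shows the effect of this change in this assay, because the limit of > 250 ug/mL in this assay, at which 2 of the 3 values shown sit, leaves the starting point itself unknown. Within the data shown here, the only guide is that compound 2 gives 95.8 ug/mL, a value that lies inside the range this assay can read. Compound 4 is therefore expected to move by an at least 1.6-fold lower number from compound 1 to compound 4 (0.22 log units; that floor lies within the scatter) in this assay, with a fair chance that it, too, ends at a limit. The estimate for compound 4 is 150 ug/mL, expected between 60 ug/mL and 300 ug/mL.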

Compound 4, concentration for 50% growth inhibition: > 250 ug/mL
Compound 4 ended at the assay's limit; the forecaster's own chance of this, stated with the estimate: 50%; middle value at least 1.6-fold (0.22 log units) from the limit.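

In this assay the result adds one readable step, an at least 2.6-fold higher number from compound 2 to compound 4 (0.41 log units; beyond the scatter). Within the data shown here, that size is only a floor, as compound 4 gives a limit of the assay and not a number, yet it shows that the drawn configuration at the saturated ring carbon matters, a point the earlier compounds could not show: the fact that compounds 2 and 4 differ only in the configuration as drawn. The steps among compound 1, compound 3 and compound 4 cannot be read, so the change from benzyl to methyl has no measurable size here: the limit of > 250 ug/mL in this assay, at which 3 of the 4 values shown sit.

From the compounds shown here alone, it remains open whether the configuration drawn in compound 2 would also give a readable number with benzyl or with the trichloromethyl-bearing chain of compound 3. Also open, going by these compounds, is what a carboxylic acid, or a longer chain in place of methyl, would give with either configuration.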